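The compounds below may be only part of what the source reports. "The series", "measured", "known", "first", "only" and "open" are said of these compounds alone.

Compound 1 `C=C(Br)C(=O)Nc1ccc(C(=O)/C=C/c2ccccc2)cc1`: 500 nM
Compound 2 `C=C(Br)C(=O)Nc1ccc(C(=O)/C=C/c2cccc(OC)c2)cc1`: 1100 nM
Compound 3 `COc1cc(/C=C/C(=O)c2ccc(N)cc2)cc(OC)c1`: 7500 nM

In a functional assay on MOLT-4 cells (Homo sapiens) for antiproliferative activity, with a stated time of 48 h (a higher number here means a weaker inhibitor, a lower number a stronger inhibitor), compound 1 gives 500 nM and compound 2 gives 1100 nM. The two differ by methoxy in place of hydrogen on an aromatic carbon, and the step is a 2.2-fold higher number from compound 1 to compound 2 (0.34 log units; beyond the scatter). Compound 3 gives 7500 nM in this assay; how its core differs from that of compound 1 is not broken down here, and the values alone show compound 3 carrying the highest number of the three.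

Compound 4 `COc1cc(/C=C/C(=O)c2ccc(N)cc2)cc(OC)c1OC` has not yet been measured in this assay. It differs from compound 3 by methoxy in place of hydrogen on an aromatic carbon. This is the same kind of change as from compound 1 to compound 2, but not the same: in compound 2 the methoxy sits meta to a large group, while in compound 4 it sits ortho to two methoxy groups and para to a large group.

Within the data shown here, the step from compound 3 to compound 4 is expected to be a 1.2-fold higher number from compound 3 to compound 4 (0.08 log units; within the scatter), resting on the one measured instance of this kind of change, a 2.2-fold higher number from compound 1 to compound 2 (0.34 log units; beyond the scatter), with the differing place widening the range. Compound 4 is estimated at 9000 nM, between 2500 nM and 35000 nM.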

Compound 4, half-maximal inhibitory concentration: 5600 nM
The estimate for compound 4 lay 1.6-fold (0.21 log units) above the measured number; the range from low to high includes it.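

In this assay, methoxy in place of hydrogen on an aromatic carbon gives a 1.3-fold lower number from compound 3 to compound 4 (0.13 log units; within the scatter), so on this core the change has no effect that can be told from the scatter. The change therefore does not carry over from one core to the other as a step of fixed size: the same change on two cores in this assay, a 2.2-fold higher number (0.34 log units; beyond the scatter) from compound 1 to compound 2 and a 1.3-fold lower number (0.13 log units; within the scatter) from compound 3 to compound 4, 2.9-fold (0.47 log units) apart, beyond the scatter of two such steps This does not show that the core alone sets the size of the step, since the methoxy also stands in a different place in each pair, and with a single pair on each core the two cannot be separated, nor do these values give a reason for the gap.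

The compounds shown leave open how the step would turn out with the methoxy in the same place on both cores. They also leave open whether a hydroxyl group, an ethoxy group or a chlorine atom in place of the added methoxy would behave as the methoxy does on either core.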